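This account rests on a few compounds, and the source may have more. Where it says the series, first, only, none or still open, it means among the compounds named here.

Results so far in an ADME assay on HepG2 cells (Homo sapiens) for cytotoxicity, read by MTT assay, with a stated time of 48 h (a higher number here means a weaker inhibitor, a lower number a stronger inhibitor), are given here for each compound:

- compound 1 `CC(C)CN1C(=O)/C(=C/c2ccc(Cl)cc2)S/C1=N\c1ccccc1` ("not determined" (no result reported))
- compound 2 `COc1ccc(/C=C2\S/C(=N\c3ccccc3)N(CC(C)C)C2=O)cc1OC` (> 100000 nM)
- compound 3 `Cc1ccc(/C=C2\S/C(=N\c3ccccc3)N(CC(C)C)C2=O)cc1` ("not determined" (no result reported))

Compound 3 has no single number to its name, and its entry reads "not determined" (no result reported) with no result behind it. The same is true of compound 1. Among the compounds with values here, the only real reading in the set belongs to compound 2, and it is a limit and not a number: > 100000 nM in this assay is all that can be said of it.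

Compound 4 `COc1cc(/C=C2\S/C(=N\c3ccccc3)N(CC(C)C)C2=O)ccc1O` has not been measured yet. The structural change is 4-hydroxy-3-methoxyphenyl in place of 4-methylphenyl on a double-bonded chain carbon bound to a double-bonded ring carbon and it puts 4-hydroxy-3-methoxyphenyl in place of 4-methylphenyl on a double-bonded chain carbon bound to a double-bonded ring carbon. The rest of the molecule stays the same.

With no number for compound 3, the size of this step cannot be read directly. The expectation is therefore a modest one: no step beyond the scatter in this assay and no clear direction, with the result staying in the region marked by the limit of compound 2 at > 100000 nM on this scale.

Compound 4 is estimated at 100000 nM in this assay with the expected range running from 40000 nM to 200000 nM and a strong chance of only a limit.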

Compound 4, half-maximal inhibitory concentration: 89500 nM
Compound 4: the middle estimate sits 1.1-fold (0.05 log units) above what was measured; measured number inside the range.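

In this assay, within the data shown here, compound 4 gives 89500 nM, the first single number in this set, so a reading now stands for a 4-hydroxy-3-methoxyphenyl group on a double-bonded chain carbon bound to a double-bonded ring carbon. Hydrogen in place of methyl on an oxygen on an aromatic ring gives an at least 1.1-fold lower number from compound 2 to compound 4 (0.04 log units; that floor lies within the scatter), which makes this the one comparison available, and it shows only a floor and no clear change in either direction. On these data alone, compound 2 still has only a limit, so the true size of this step stays unknown: the limit of > 100000 nM in this assay, at which 1 of the 4 values shown sits.

Steps involving compound 1 or compound 3 cannot be read, which leaves the swap of 4-methylphenyl for 4-hydroxy-3-methoxyphenyl without a size and the 4-chlorophenyl group of compound 1 without any reading at all. The compounds shown also leave open whether an amine or a carboxylic acid on this aromatic ring, at the same place on the chain carbon, would give a number clearly apart from that of compound 4.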